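A few compounds are considered here, and "the series" means these few. Any claim that something is new, unique, unknown or untested is made for them only; others in the source may bear on it.

Measured in an ADME assay on MDCKII-LE cells (Canis lupus familiaris) for permeability, in the apical to basolateral direction; a higher number here means that the compound crosses the layer faster, a lower number that the compound crosses the layer more slowly:
compound 1 `Cc1csc2nc(Cn3cnc4ccccc43)cc(=O)n12` gives 23.4 10^-6 cm/s
compound 2 `Cc1cn2c(=O)cc(Cn3cnc4ccccc43)nc2s1` gives 14.3 10^-6 cm/s

Compound 2 (14.3 10^-6 cm/s) lies within the scatter of compound 1 (23.4 10^-6 cm/s), so these two values cannot be told apart. Next is compound 3 `Cc1sc2nc(Cn3cnc4ccccc43)cc(=O)n2c1C`, not yet measured, which departs from compound 2 by a single change: methyl in place of hydrogen on an aromatic carbon. The site is on the five-membered aromatic ring with 1 nitrogen and 1 sulfur, next to the ring nitrogen and next to the ring atom that bears a methyl group.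

For the measured compounds named here, no measured pair differs in one place, so this kind of change has no direct precedent. Going by the values given here, the only guide is that compound 1 and compound 2 stay within the scatter of each other in this assay. No step beyond the scatter is expected, and no direction can be argued with confidence. The estimated change is small (a 1.3-fold higher number from compound 2 to compound 3 (0.10 log units; within the scatter)). For compound 3 the expected value is 18 10^-6 cm/s, with 9 10^-6 cm/s to 36 10^-6 cm/s as the expected range.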

Compound 3, apparent permeability: 22.9 10^-6 cm/s
Beside the measured number, compound 3's estimate is 1.3-fold (0.10 log units) below it, and the stated range covers the measured number.
By their numbers in this assay, from the lowest: compounds 2, 3 and 1 (each within the scatter of the next).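

In this assay, for the compounds shown here, the first reading of methyl in place of hydrogen on an aromatic carbon gives a 1.6-fold higher number from compound 2 to compound 3 (0.20 log units; within the scatter), with the methyl next to the ring nitrogen and next to the ring atom that bears a methyl group. Read from the other single-methyl compound, the same kind of change gives a 1.0-fold lower number from compound 1 to compound 3 (0.01 log units; within the scatter), so both steps stay within the scatter and the series now holds compounds with this ring carrying either one methyl group or two without any step beyond it. No measurement at hand accounts for these numbers or links them to any property of the methyl group.

The compounds shown leave open whether anything other than methyl on this aromatic carbon, such as an ethyl chain, an amine or a carboxylic acid, would give a step beyond the scatter. Going by these compounds alone, they also leave open how this assay responds to changes elsewhere on the shared core, since every step so far involves methyl in place of hydrogen on the same five-membered aromatic ring.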